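From ethoxycarbonyl to 3,4-dichlorophenyl on the double-bonded chain

A few compounds are considered here, and "the series" means these few. Any claim that something is new, unique, unknown or untested is made for them only; others in the source may bear on it.

Three compounds were measured in a functional assay on SEM cells (Homo sapiens) for cytotoxicity, with a stated time of 72 h (a lower number here means that less compound is needed, a higher number that more compound is needed for the effect), as follows
Compound 1 `C=C[C@@](C)(/C=C/c1ccc(O)c(CO)c1)CCC=C(C)C` gives > 36600 nM (a limit)
Compound 2 `C=C[C@@](C)(/C=C/c1ccc(O)c(C=O)c1)CCC=C(C)C` gives 8510 nM (a number)
Compound 3 `C=C[C@@](C)(/C=C/c1ccc(O)c(/C=C/C(=O)OCC)c1)CCC=C(C)C` gives > 36600 nM (a limit)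

Compound 3 thus stands at a limit of this assay and not at a number, as the limit of > 36600 nM in this assay, at which 2 of the 3 values shown sit, makes clear. The change to compound 4 `C=C[C@@](C)(/C=C/c1ccc(O)c(/C=C/c2ccc(Cl)c(Cl)c2)c1)CCC=C(C)C` is 3,4-dichlorophenyl in place of ethoxycarbonyl on a double-bonded chain carbon bound to a double-bonded chain carbon and puts 3,4-dichlorophenyl where ethoxycarbonyl stood. Going by the values given here, no measured step exchanges that ethoxycarbonyl itself. Two measured steps at the aromatic carbon carrying this chain moved the number, an at least 4.3-fold lower number from compound 1 to compound 2 (0.63 log units; beyond the scatter) and an at least 4.3-fold higher number from compound 2 to compound 3 (0.63 log units; beyond the scatter) in turn, and a step that the two limits leave unreadable from compound 1 to compound 3 adds no readable size. A modest at least 2.4-fold lower number from compound 3 to compound 4 (0.38 log units; beyond the scatter) toward a lower number is expected, though another limit remains possible. Compound 4 is estimated at 15000 nM (range 5000 nM to 36000 nM).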

Compound 4, half-maximal effective concentration: > 7500 nM
Compound 4 gave a limit, no number (the forecaster's own chance of this, stated with the estimate: 35%); the middle value lies beyond the limit too.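

Compound 3 and compound 4 both give limits rather than numbers in this assay, and the step between them cannot be read. From the compounds shown here alone, whether 3,4-dichlorophenyl in place of ethoxycarbonyl changes the number at all, and in which direction, remains open.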